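Swapping the benzyl carbamate for an acyloxymethyl carbamate

This account rests on a few compounds, and the source may have more. Where it says the series, first, only, none or still open, it means among the compounds named here.

Compound 1 `C[C@@H]1CN(C(=O)c2nc(Nc3cc(C4CC4)[nH]n3)c3cc(Cl)ccc3n2)CCN1C(=O)OCc1ccccc1`: 45.6%
Compound 2 `CC(OC(=O)C(C)C)OC(=O)N1CCN(C(=O)c2nc(Nc3cc(C4CC4)[nH]n3)c3cc(Cl)ccc3n2)C[C@H]1C`: 11%

Of the compounds shown here, two have been measured in an ADME assay on S9 fraction from liver (Rattus norvegicus), read by LC-MS, with a stated time of 60 min, at 37 degrees C; on this read-out lower numbers stand for a less stable compound and higher numbers for a more stable compound. Compound 1 gives 45.6%, the higher of the two numbers. Compound 2 gives 11%. Among the measured compounds shown here, the one step between them, a number 34.6 percentage points lower from compound 1 to compound 2 (beyond the scatter), is large and beyond the scatter, and it comes from the change of 1-((isopropylcarbonyl)oxy)ethyl in place of benzyl on an oxygen next to a carbonyl group.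

Compound 3 `C[C@@H]1CN(C(=O)c2nc(Nc3cc(C4CC4)[nH]n3)c3cc(Cl)ccc3n2)CCN1C(=O)OCOC(=O)C(C)(C)C` is not yet measured. It differs from compound 1 by ((tert-butyl)carbonyl)oxy in place of phenyl on a saturated chain carbon bound to an oxygen next to a carbonyl group, a change of the same kind as the step from compound 1 to compound 2 in that the benzyl is again replaced by an acyloxyalkyl group. Since a number 34.6 percentage points lower from compound 1 to compound 2 (beyond the scatter) was large, a drop of similar size in this assay is expected for compound 3, the step being estimated as a number 30.6 percentage points lower from compound 1 to compound 3 (beyond the scatter). The estimate for compound 3 is therefore 15%, with a range from 3% to 35%.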

Compound 3, percent of the compound remaining: 47%
Compound 3: the middle estimate sits 32 percentage points below what was measured; measured number outside the range, above it.
By their numbers in this assay, from the lowest: compound 2; then compounds 1 and 3 (each within the scatter of the next).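

The change of phenyl to ((tert-butyl)carbonyl)oxy on a saturated chain carbon bound to an oxygen next to a carbonyl group gives a number 1.4 percentage points higher from compound 1 to compound 3 (within the scatter) in this assay, so an acyloxyalkyl group in place of the benzyl does not in itself set compound 2 apart from compound 1. The low number is specific to the group in compound 2, as (((tert-butyl)carbonyl)oxy)methyl in place of 1-((isopropylcarbonyl)oxy)ethyl on an oxygen next to a carbonyl group gives a number 36 percentage points higher from compound 2 to compound 3 (beyond the scatter). Nothing available explains this gap.

Compounds 2 and 3 differ both in the acyl part and in the carbon that carries it, so the compounds shown do not tell which of the two matters. An ((isopropylcarbonyl)oxy)methyl group or a 1-(((tert-butyl)carbonyl)oxy)ethyl group on the same oxygen would separate them.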